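The source may hold more compounds than are shown below. What is called first, only, known or untested is meant among the compounds shown, and "the series" means these compounds.

Measured so far:
compound 1, `CC(=O)NCC(=O)Nc1ccc(Cl)cc1C(=O)c1ccccc1`: > 100 mg/kg
compound 2, `CN1CCN(CC(=O)NCC(=O)N(C)c2ccc(Cl)cc2C(=O)c2ccccc2Cl)CC1`: > 100 mg/kg

Both results shown in a functional assay on the whole organism with Mus musculus as the target, in the rotarod test (a higher number here means that more compound is needed for the effect, a lower number that less compound is needed), are limits of the assay rather than numbers. For compound 1 the result > 100 mg/kg is such a limit. For compound 2 the result > 100 mg/kg is likewise a limit. For the measured compounds named here, compound 2 thus stands at the limit of > 100 mg/kg in this assay, at which 2 of the 2 values shown sit, and no step between measured compounds is available.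

The next compound, compound 3, `CN(C)CC(=O)NCC(=O)N(C)c1ccc(Cl)cc1C(=O)c1ccccc1Cl`, differs from compound 2 in one place: dimethylamino in place of 4-methylpiperazin-1-yl on a saturated chain carbon bound to a carbonyl carbon, 4-methylpiperazin-1-yl giving way to dimethylamino on the saturated chain carbon bound to the carbonyl carbon. Going by the values given here, no measured step tells how this change moves the dose in this assay; the expectation is no step beyond the scatter, the estimated step being a step that the limit leaves unreadable from compound 2 to compound 3. For compound 3 the expected dose in this assay is 150 mg/kg, within a range from 60 mg/kg to 400 mg/kg. The result for compound 3 is expected most likely to be a limit again because compound 2 sits at the limit of > 100 mg/kg in this assay, at which 2 of the 2 values shown sit.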

Compound 3, dose for half-maximal effect: 26 mg/kg
For compound 3 the middle estimate is 5.8-fold (0.76 log units) above the measured one; the whole stated range lies above it.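

In this assay, dimethylamino in place of 4-methylpiperazin-1-yl on the saturated chain carbon bound to a carbonyl carbon gives an at least 3.8-fold lower number from compound 2 to compound 3 (0.58 log units; beyond the scatter). This place in the series therefore responds to the change in the group, and compound 3 gives a measured number, 26 mg/kg, rather than a limit. The full size of the step cannot be read because the starting value is only a limit: the limit of > 100 mg/kg in this assay, at which 2 of the 3 values shown sit.

The compounds shown do not separate the loss of the ring from the loss of the second nitrogen, and piperidin-1-yl or morpholin-4-yl in the same place would bear on that. On these data alone, it also stays open whether a larger open-chain amine such as diethylamino keeps the lower number seen with dimethylamino.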